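A few compounds are considered here, and "the series" means these few. Any claim that something is new, unique, unknown or untested is made for them only; others in the source may bear on it.

Two ureas built on the same core have been measured in an ADME assay for permeability, using PAMPA, at pH 7.4; on this read-out lower numbers stand for lower permeability and higher numbers for higher permeability. Compound 1, `Cc1cc(NC(=O)Nc2ccc(Cl)c(Cl)c2)c2ccccc2n1`, gives 197 10^-6 cm/s in this assay. Compound 2, `CCc1ccc(NC(=O)Nc2cc(C)nc3ccccc23)cc1`, gives 535 10^-6 cm/s, and of the two numbers this is the higher one; the gap from compound 1 to compound 2 lies beyond the usual scatter of the measurement. Going by the values given here, no pair among the measured compounds differs in only one place, so no single-point step can be read from them.

Compound 3, `COc1ccc(NC(=O)Nc2cc(C)nc3ccccc23)cc1`, has not yet been measured in this assay. It differs from compound 2 as follows: methoxy in place of ethyl on an aromatic carbon. Among the compounds with values here, with no measured step of this kind to lean on, a modest downward move is expected, and the step from compound 2 to compound 3 is estimated at a 1.6-fold lower number from compound 2 to compound 3 (0.20 log units; within the scatter). For compound 3 the expected value in this assay is 340 10^-6 cm/s, with a range from 150 10^-6 cm/s to 650 10^-6 cm/s.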

Compound 3, apparent permeability: 787 10^-6 cm/s
For compound 3 the middle estimate is 2.3-fold (0.36 log units) below the measured one, and the stated range ends below it.
By their numbers in this assay, from the lowest: compound 1; then compounds 2 and 3 (each within the scatter of the next).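

Placing methoxy in place of ethyl on an aromatic carbon, para to a large group, gives in this assay a 1.5-fold higher number from compound 2 to compound 3 (0.17 log units; within the scatter). Going by these compounds alone, this is the first single-place comparison, and it shows that on this read-out the two groups cannot be told apart at this position, even though the change brings in an oxygen and a hydrogen-bond acceptor while the heavy-atom count stays the same. Nothing measured here bears on why the two compounds read alike.

Steps to compound 1 cannot be read, as it differs from compound 2 and compound 3 in more than one place. As far as these compounds go, whether the number at this position would hold with an amine, a carboxylic acid or a longer chain stays open, as does whether methoxy for ethyl would read the same on another ring carbon.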